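A Small Chain Step, Then an Oxygen

The source may hold more compounds than are shown below. What is called first, only, known or untested is meant among the compounds shown, and "the series" means these compounds.

Among the compounds with values here, in a functional assay on the whole organism (strain Wistar) for inhibition, with Rattus norvegicus as the target (on this read-out higher numbers stand for an effect only at larger amounts of compound and lower numbers for an effect already at smaller amounts), compound 1 `Cc1ccc2c(O)c(C#N)c(=O)oc2c1` gives 52.4 umol/kg and compound 2 `CCc1ccc2c(O)c(C#N)c(=O)oc2c1` gives 23.8 umol/kg as the lower of the two numbers so far. Within the data shown here, the only measured step is a 2.2-fold lower number from compound 1 to compound 2 (0.34 log units; beyond the scatter) and it is modest, though beyond the scatter. It comes with methyl in place of hydrogen on a saturated chain carbon bound to an aromatic carbon.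

Compound 3 `CCOc1ccc2c(O)c(C#N)c(=O)oc2c1` keeps the shared core but has ethoxy in place of ethyl on an aromatic carbon. Among the measured compounds shown here, no measured compound carries an oxygen in this group, so the step of a 2.2-fold lower number from compound 1 to compound 2 (0.34 log units; beyond the scatter) is only a loose guide. It suggests that a small change to this group can move the number modestly, but it does not fix a direction for this new change. A modest step at most is therefore expected in this assay with a slight lean towards a lower number. The estimated change is a 1.2-fold lower number from compound 2 to compound 3 (0.08 log units; within the scatter) and may well stay within the scatter. For compound 3 the estimate is 20 umol/kg with an expected range of 9 umol/kg to 48 umol/kg on this measure.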

Compound 3, dose for half-maximal effect: 15.1 umol/kg
Compound 3: the middle estimate sits 1.3-fold (0.12 log units) above what was measured, and the stated range covers the measured number.
By their numbers in this assay, from the lowest: compounds 3 and 2 (each within the scatter of the next); then compound 1.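

In this assay, swapping ethyl for ethoxy on this aromatic carbon gives a 1.6-fold lower number from compound 2 to compound 3 (0.20 log units; within the scatter) and so does not separate the two groups, even though ethoxy adds an oxygen and the one hydrogen-bond acceptor counted for it. The comparison with the smallest group says more: the change from methyl to ethoxy gives a 3.5-fold lower number from compound 1 to compound 3 (0.54 log units; beyond the scatter) and shows that this position accepts a group with an oxygen attached directly to the ring while the number stays clearly lower than that of compound 1, so compounds 2 and 3 both stand apart from compound 1 but not from each other. Nothing measured here on the compounds themselves offers an explanation for these numbers.

Open, as far as these compounds go, is whether the oxygen matters at all at this position, which a pair such as methoxy and a propyl chain could help to test against the present three groups. Also open, from the compounds shown here alone, is how far the position stretches, since a longer chain such as butoxy, or an amine or a carboxylic acid in the same place, could behave quite differently from ethoxy.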